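The source may hold more compounds than are shown below. What is called first, only, known or untested is meant among the compounds shown, and "the series" means these compounds.

In a functional assay on CAL-51 cells (Homo sapiens) for antiproliferative activity, read by luminescence and CellTiter-Glo, with a stated time of 3 days (a higher number here means a weaker inhibitor, a lower number a stronger inhibitor), compound 1 `C[C@@H](Oc1cc(C(=O)N(C)C)ccc1Nc1nc(O[C@H]2CC[C@@](C)(O)CC2)c2cc[nH]c2n1)C(F)(F)F` gives 24 nM and compound 2 `COc1cc(N2CCC(C)(O)CC2)ccc1Nc1nc(O[C@H]2CCOC(C)(C)C2)c2cc[nH]c2n1` gives 71 nM. Compound 2 therefore holds the higher of the two numbers, making it the weaker inhibitor of the pair, and the gap between them lies beyond the usual scatter. The two compounds differ in more than one place, so they isolate no single change. Compound 3 `COc1cc(N2CCN(C(=O)CO)CC2)ccc1Nc1nc(O[C@H]2CCOC(C)(C)C2)c2cc[nH]c2n1` keeps the core of compound 2 and alters one substituent: 4-((hydroxymethyl)carbonyl)piperazin-1-yl in place of 4-hydroxy-4-methylpiperidin-1-yl on an aromatic carbon. The exchange takes place on an aromatic carbon, meta to a methoxy group and para to a large group. Within the data shown here, no measured pair shows the effect of such an exchange in this assay, so no shift beyond the scatter is expected in either direction. The estimated change is a 1.2-fold lower number from compound 2 to compound 3 (0.07 log units; within the scatter). For compound 3, the expected value is 60 nM, with an estimated range of 20 nM to 180 nM.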

Compound 3, half-maximal inhibitory concentration: 37 nM
The estimate for compound 3 lay 1.6-fold (0.21 log units) above the measured number, and the stated range covers the measured number.
By their numbers in this assay, from the lowest: compounds 1, 3 and 2 (each within the scatter of the next, the first and the last beyond it).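

In this assay, the aromatic carbon meta to a methoxy group and para to a large group accepts 4-((hydroxymethyl)carbonyl)piperazin-1-yl in place of 4-hydroxy-4-methylpiperidin-1-yl, with a 1.9-fold lower number from compound 2 to compound 3 (0.28 log units; within the scatter). Among these compounds, this is the first single-place comparison, and it shows that this exchange, which brings a second ring nitrogen and a carbonyl and raises the heavy-atom count, gives no shift beyond the scatter. No measurement available bears on why the result falls this way.

The compounds shown leave open whether the hydroxyl of the entering group matters, which a plain acetyl group on the piperazine would test. They also leave open how a carboxylic acid or a primary amine on a longer chain would fare at this position.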